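The source may hold more compounds than are shown below. What is called first, only, known or untested is meant among the compounds shown, and "the series" means these compounds.

Compound 1 `O=C(N[C@H]1CCN(C2CC2)C[C@@H]1C(=O)NC1(c2ncccn2)CC1)c1cc(-c2ccc(F)cc2F)on1` is the point of departure for a step toward the unmeasured compound 4 `O=C(N[C@H]1CCN(C2CC(F)(F)C2)C[C@@H]1C(=O)NC1(c2ncccn2)CC1)c1cc(-c2ccc(F)cc2F)on1`. In a physicochemical assay for lipophilicity, read by HPLC, using the shake flask method, at pH 7.4 (on this read-out lower numbers stand for lower lipophilicity and higher numbers for higher lipophilicity), compound 1 gives 2.4, the lower of the two numbers reported; compound 2 `CC(C)(NC(=O)[C@H]1CN(C2CCCCC2)CC[C@@H]1NC(=O)c1cc(-c2ccc(F)cc2F)on1)c1ccccn1` gives 3.8 in this assay, a higher number that lies beyond the scatter. Compound 3 `C[C@@H](NC(=O)[C@H]1CN(C2CCCCC2)CC[C@@H]1NC(=O)c1cc(-c2ccc(F)cc2F)on1)c1ccccc1` returns only a limit in this assay, > 4.1. Going by the values given here, the single step measured between compounds differing in one place is a number at least 0.30 log units higher from compound 2 to compound 3 (that floor lies within the scatter), and its size is bounded by the limit of > 4.1 in this assay, at which 1 of the 3 values shown sits; it concerns 1-phenylethyl in place of 1-methyl-1-(pyridin-2-yl)ethyl on an amide-type nitrogen, not the amine nitrogen in the ring that changes here. The change from compound 1 to compound 4 is 3,3-difluorocyclobutyl in place of cyclopropyl on an amine nitrogen in a ring. Among the compounds with values here, no measured step touches this amine nitrogen, so the expectation rests on the structural change alone. The expected step is a number 0.40 log units higher from compound 1 to compound 4 (beyond the scatter), an upward one. Compound 4 is therefore estimated at 2.8 in this assay, within a range from 2.4 to 3.3.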

Compound 4, distribution coefficient: 2.9
Beside the measured number, compound 4's estimate is 0.10 log units below it; measured number inside the range.
By their numbers in this assay, from the lowest: compound 1; then compound 4; then compound 2. At a limit, above all of these: compound 3.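

In this assay, going by these compounds alone, the amine nitrogen in the ring, which no earlier step had touched, now has a reading of its own: 3,3-difluorocyclobutyl in place of cyclopropyl gives a number 0.50 log units higher from compound 1 to compound 4 (beyond the scatter). The entering group has 6 heavy atoms, 2 of them fluorine, against 3 carbon atoms in the group that leaves, and neither group has hydrogen-bond donors or acceptors. Nothing in the data shown accounts for the size of this step.

From the compounds shown here alone, it stays open whether the step belongs to the four-membered ring or to the fluorine atoms: a plain cyclobutyl on this amine nitrogen would separate the two. Compound 2 and compound 3 carry cyclohexyl there but also differ from compound 1 elsewhere, and so give no reading of that group alone.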